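Lengthening the alkoxy chain on a nitro-sulfonamide core

The source may hold more compounds than are shown below. What is called first, only, known or untested is meant among the compounds shown, and "the series" means these compounds.

Within the data shown here, compound 2 `CCC(CC)Oc1cc([N+](=O)[O-])ccc1NS(C)(=O)=O` gives the lowest of the two numbers recorded so far in an assay on SK-BR-3 cells for inhibition of Aromatase (Homo sapiens) (a lower number here means a stronger inhibitor, a higher number a weaker inhibitor), namely 300 nM; its only neighbour, compound 1 `CC(C)Oc1cc([N+](=O)[O-])ccc1NS(C)(=O)=O`, gives 5870 nM in this assay, and the step of a 20-fold lower number from compound 1 to compound 2 (1.29 log units; beyond the scatter) lies beyond the scatter. Compound 3 `CCCCCCOc1cc([N+](=O)[O-])ccc1NS(C)(=O)=O` carries hexyl in place of pentan-3-yl on an oxygen on an aromatic ring. Among the measured compounds shown here, the one measured step that bears on this change is a 20-fold lower number from compound 1 to compound 2 (1.29 log units; beyond the scatter), where a larger alkyl group on the same oxygen lowered the number strongly; compound 3 grows the group by one carbon but also straightens it, and no measured pair shows what a straight chain does here. Compound 3 is therefore expected to stay near compound 2, with a 1.5-fold lower number from compound 2 to compound 3 (0.18 log units; within the scatter), not beyond the scatter. Compound 3 is estimated at 200 nM in this assay, within a range of 50 nM to 1000 nM.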

Compound 3, half-maximal inhibitory concentration: 2670 nM
Beside the measured number, compound 3's estimate is 13-fold (1.13 log units) below it, outside the stated range (above it).
By their numbers in this assay, from the lowest: compound 2; then compound 3; then compound 1.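

In this assay, adding carbon to the alkyl group on this oxygen does not by itself lower the number: the change from pentan-3-yl to hexyl gives a step beyond the scatter in the opposite direction to the earlier one (an 8.9-fold higher number from compound 2 to compound 3 (0.95 log units; beyond the scatter)). Hexyl still improves on isopropyl, but only modestly (a 2.2-fold lower number from compound 1 to compound 3 (0.34 log units; beyond the scatter)), so pentan-3-yl remains the best of the three groups shown. Compound 3 therefore goes against any simple rule that a larger alkyl group gives a lower number, and the order depends on more than the carbon count.

The compounds shown leave open how a cyclopentyl ring, a longer chain or an amine at the end of the chain would fare on this oxygen. No measurement at hand explains why pentan-3-yl and hexyl differ.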